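This account rests on a few compounds, and the source may have more. Where it says the series, first, only, none or still open, it means among the compounds named here.

Compound 1 `COc1cc(C(=O)NNC(=S)Nc2csc(-c3ccc(C)cc3)c2)cc(OC)c1OC`: 47000 nM
Compound 2 `COc1cc(OC)cc(C(=O)NNC(=S)Nc2csc(-c3ccccc3)c2)c1`: 40000 nM

Both compounds were tested in a functional assay on U-373MG ATCC cells (Homo sapiens) for inhibition, read by colorimetric assay and MTT assay, with a stated time of 72 h; a lower number here means a stronger inhibitor, a higher number a weaker inhibitor. Compound 1 gives 47000 nM in this assay, and compound 2 gives 40000 nM. Compound 2 thus has the lesser of the two numbers, but its gap to compound 1 lies within the usual scatter, so the two cannot be told apart on this evidence. Among the compounds with values here, the two compounds also differ in more than one place, so no single step between them can be read off.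

Compound 3 `COc1cc(OC)cc(C(=O)NNC(=S)Nc2csc(-c3ccc(C)cc3)c2)c1` is the unmeasured member. It differs from compound 2 by methyl in place of hydrogen on an aromatic carbon. Within the data shown here, nothing among the measured pair isolates this change; compound 1 carries the same 4-methylphenyl group but on a different core, and its number sits beside that of compound 2 within the scatter. On that basis the step from compound 2 to compound 3 in this assay is expected to be small, in no particular direction, and is estimated as no change at the digits printed from compound 2 to compound 3 (within the scatter). Compound 3 is accordingly expected to give about 40000 nM in this assay, with a range from 15000 nM to 100000 nM.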

Compound 3, half-maximal inhibitory concentration: 41000 nM
Compound 3: middle estimate off by 1.0-fold (0.01 log units), on the low side; measured number inside the range.
By their numbers in this assay, from the lowest: compounds 2, 3 and 1 (each within the scatter of the next).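

In this assay, the change from phenyl to 4-methylphenyl now stands alone on an otherwise unchanged structure: methyl in place of hydrogen on an aromatic carbon, para to a large group, gives a 1.0-fold higher number from compound 2 to compound 3 (0.01 log units; within the scatter). Compound 3 also connects compound 1 to this pair through a single change, hydrogen in place of methoxy on an aromatic carbon, which gives a 1.1-fold lower number from compound 1 to compound 3 (0.06 log units; within the scatter). Neither this methyl nor this methoxy separates the compounds concerned in this assay, and no supporting measurement is available to explain either step.

The compounds shown leave open whether a different group at the position that carries the methyl, such as an amine, a carboxylic acid or a longer chain, would give a step beyond the scatter. They also leave open whether a change in another part of the shared structure would give a number clearly apart from those of compound 1, compound 2 and compound 3.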